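The source may report more compounds than this note shows. Statements on the series, on what has been measured and on what is new or still open speak of the compounds shown alone.

Compound 1 `CN(CCC#N)C[C@H]1CN(c2ccc(-n3cc(-c4ccccn4)cn3)c(F)c2)C(=O)O1` is the starting point of this step. In an ADME assay on L02 cells (Homo sapiens) for cytotoxicity, read by MTT assay, with a stated time of 48 h (on this read-out higher numbers stand for weaker inhibition and lower numbers for stronger inhibition), compound 1 gives > 400 ug/mL, which is a limit of the assay rather than a measured number. Compound 2 `O=C1CCC(=O)N1C[C@H]1CN(c2ccc(-n3cc(-c4ccccn4)cn3)c(F)c2)C(=O)O1` gives > 400 ug/mL in this assay, again a limit. Compound 3 `CCC(=O)NC[C@H]1CN(c2ccc(-n3cc(-c4ccccn4)cn3)c(F)c2)C(=O)O1` gives 204 ug/mL in this assay, a true number. Two of the three values thus sit at the limit of > 400 ug/mL in this assay, at which 2 of the 3 values shown sit, so most of the room here is only one-sided. The step that the two limits leave unreadable from compound 1 to compound 2 cannot be read, while an at least 1.9-fold lower number from compound 1 to compound 3 (0.29 log units; that floor lies within the scatter) and an at least 1.9-fold lower number from compound 2 to compound 3 (0.29 log units; that floor lies within the scatter) each have a floor that still lies inside the usual scatter. Compound 4 `O=CNC[C@H]1CN(c2ccc(-n3cc(-c4ccccn4)cn3)c(F)c2)C(=O)O1` has not yet been measured. It differs from compound 1 by formylamino in place of (2-cyanoethyl)(methyl)amino on a saturated chain carbon bound to a saturated ring carbon. The closest measured guide is the move to compound 3, propanoylamino in place of (2-cyanoethyl)(methyl)amino on a saturated chain carbon bound to a saturated ring carbon, a step whose readable floor is small. For compound 4 the expected step is an at least 1.3-fold lower number from compound 1 to compound 4 (0.12 log units; that floor lies within the scatter), at most a modest move toward a lower number. Compound 4 is estimated at 300 ug/mL, between 140 ug/mL and 600 ug/mL.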

Compound 4, half-maximal inhibitory concentration: > 400 ug/mL
Compound 4 ended at the assay's limit (the forecaster's own chance of this, stated with the estimate: 50%); at least 1.3-fold (0.12 log units) between middle value and limit.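

Hydrogen in place of ethyl on the carbonyl carbon is the first change here that keeps the nitrogen and its carbonyl in place, and in this assay it reads as an at least 1.9-fold higher number from compound 3 to compound 4 (0.29 log units; that floor lies within the scatter). The steps from compound 1 and from compound 2 to compound 4 cannot be read, and the assay's limit now holds most of the set: the limit of > 400 ug/mL in this assay, at which 3 of the 4 values shown sit. Of the four groups on this saturated chain carbon, only propanoylamino gives a true number, yet the readable gap may still be no more than scatter.

As far as these compounds go, how far the true values of compound 1, compound 2 and compound 4 lie from one another remains open. Also open, from the compounds shown here alone, is whether acetylamino or the longer butanoylamino would give a true number, which would show whether the carbon chain on the carbonyl matters at this position.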